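Swapping Formylphenyl for Furan: Cytotoxicity Remains a Limit

This account rests on a few compounds, and the source may have more. Where it says the series, first, only, none or still open, it means among the compounds named here.

Compound 2 `O=Cc1ccc(-c2cc(Cl)cn3c([N+](=O)[O-])c(CS(=O)(=O)c4ccccc4)nc23)cc1` was tested in an ADME assay on HepG2 cells (Homo sapiens) for cytotoxicity, read by MTT assay, with a stated time of 72 h; on this read-out higher numbers stand for lower toxicity in this test and lower numbers for higher toxicity in this test. Compound 2 gives only a limit, > 31200 nM, and not a number. Its two neighbours stand the same way. Compound 1 `O=[N+]([O-])c1c(CS(=O)(=O)c2ccccc2)nc2c(-c3ccccc3)cc(Cl)cn12` gives in this assay a limit of > 15600 nM. Compound 3 `O=[N+]([O-])c1c(CS(=O)(=O)c2ccccc2)nc2c(-c3cccc(C(F)(F)F)c3)cc(Cl)cn12` gives in this assay a limit of > 12500 nM. All three values are limits, so the steps among them cannot be read: a step that the two limits leave unreadable from compound 1 to compound 2, a step that the two limits leave unreadable from compound 1 to compound 3 and a step that the two limits leave unreadable from compound 2 to compound 3. Compound 2 thus stands with the others at a limit, with no ranked place among them.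

Compound 4 `O=[N+]([O-])c1c(CS(=O)(=O)c2ccccc2)nc2c(-c3ccco3)cc(Cl)cn12` differs from compound 2 in one place: furan-2-yl in place of 4-formylphenyl on an aromatic carbon. For the measured compounds named here, the measured steps that touch this position, the one from compound 1 and the two involving compound 3, have no readable size and offer no direction. The step is expected to be an at least 1.0-fold lower number from compound 2 to compound 4 (0.01 log units; that floor lies within the scatter), none beyond the scatter. Compound 4 is estimated at 30000 nM in this assay, with a range from 10000 nM to 100000 nM, and is likely to come back as a limit once more.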

Compound 4, half-maximal cytotoxic concentration: > 3900 nM
Compound 4 was reported as a limit; the forecaster's own chance of this, stated with the estimate: 80%; the middle value is on the limit's open side.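

Compound 4 gives only a limit in this assay, as do compound 1, compound 2 and compound 3, so the steps linking compound 4 to these three cannot be read. The compounds shown leave open whether furan-2-yl differs at all from 4-formylphenyl, phenyl or 3-(trifluoromethyl)phenyl in this read-out.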